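A few compounds are considered here, and "the series" means these few. Any claim that something is new, unique, unknown or untested is made for them only; others in the source may bear on it.

Working notes on the series. Compound 1 `O=C(COc1ccc(C(=O)/C=C/c2cccc(Br)c2)cc1)N[C@H]1CCOC1=O` is the reference point. In a functional assay on PC-3 cells (Homo sapiens) for antiproliferative activity, read by MTT assay, with a stated time of 72 h (on this read-out higher numbers stand for weaker inhibition and lower numbers for stronger inhibition), compound 1 gives 7890 nM. For the measured compounds named here, compound 3 `O=C1OCC[C@@H]1NC(=S)SCCOc1ccccc1[N+](=O)[O-]` is the only other compound with a number here: in this assay compound 3 gives 24000 nM, a higher value than compound 1 by a margin that lies beyond the scatter. Compound 2 `Cc1cc(Cl)ccc1NCC(=O)N[C@H]1CCOC1=O` returns only a limit: in this assay compound 2 gives > 64000 nM, which is a limit of the assay and not a number (the limit of > 64000 nM in this assay, at which 1 of the 3 values shown sits). Among the two numbers shown, compound 1 therefore stands lowest.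

The step under consideration leads to compound 4 `O=C(COc1ccc(C(=O)/C=C/c2cccc(Cl)c2)cc1)N[C@H]1CCOC1=O`, which differs from compound 1 as follows: chloro in place of bromo on an aromatic carbon. Going by the values given here, no measured pair carries this kind of change, so there is nothing here to set its size against. A halogen swap of this kind is expected to move the number little, if at all, and the step from compound 1 to compound 4 is estimated to stay within the scatter, at a 1.0-fold higher number from compound 1 to compound 4 (0.01 log units; within the scatter). For compound 4 the expected value in this assay is 8000 nM, with a range from 4000 nM to 16000 nM.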

Compound 4, half-maximal inhibitory concentration: 4990 nM
Beside the measured number, compound 4's estimate is 1.6-fold (0.20 log units) above it; the range from low to high includes it.
By their numbers in this assay, from the lowest: compounds 4 and 1 (each within the scatter of the next); then compound 3. At a limit, above all of these: compound 2.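

For the compounds shown here, the first pair that differs in one place gives, in this assay, a 1.6-fold lower number from compound 1 to compound 4 (0.20 log units; within the scatter). At this position, on an aromatic carbon meta to a large group, chloro and bromo therefore cannot be told apart on this read-out, and the 3-chlorophenyl and 3-bromophenyl forms of the shared core read as equivalent. No measurement at hand bears on the physical basis of this result.

From the compounds shown here alone, with only these two halogens at the position, it remains open whether a halogen is needed there at all, or whether a hydrogen, a methoxy group or an amine in the same place would hold the number. Going by these compounds, compounds 2 and 3 differ from compound 1 in more than one place, so it also remains open which part of the core of compound 1 separates it from them.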